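From Nitro to Fluoro: An Expected Growth Inhibition

The source may report more compounds than this note shows. Statements on the series, on what has been measured and on what is new or still open speak of the compounds shown alone.

Compound 1 `N#C/C(=C\c1ccccc1OS(=O)(=O)c1ccc(F)cc1)C(=O)Nc1nnc(Cc2ccc(F)cc2)s1` gives 59% in the single-concentration test
Compound 2 `Cc1ccc(Cc2nnc(NC(=O)/C(C#N)=C/c3ccccc3OS(=O)(=O)c3ccc([N+](=O)[O-])cc3)s2)cc1` gives 64% in the single-concentration test

Both values come from a functional assay on RS4-11 cells (Homo sapiens) for inhibition, read by CCK-8 assay, with a stated time of 48 h, tested at 20 uM (a higher number here means more inhibition of growth at the concentration tested, a lower number less inhibition of growth), and lie within the usual scatter of each other, so compound 2 stands level with compound 1. Compound 3 `Cc1ccc(Cc2nnc(NC(=O)/C(C#N)=C/c3ccccc3OS(=O)(=O)c3ccc(F)cc3)s2)cc1` is compound 2 with fluoro in place of nitro on an aromatic carbon, para to a large group (fluoro in place of nitro on an aromatic carbon), which turns (4-nitrophenyl)sulfonyl into (4-fluorophenyl)sulfonyl. Among the measured compounds shown here, no measured step shows the size of this change directly. In this assay, the expectation is therefore for no step beyond the scatter, and this remains a judgement with little behind it. An estimated a number 4 percentage points lower from compound 2 to compound 3 (within the scatter) is expected on this view. Compound 3 is estimated at 60% with an expected range from 45% to 75% when it is measured.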

Compound 3, percent growth inhibition at one concentration: 73%
Estimate against measurement, compound 3: 13 percentage points below; low and high end bracket the measured number.
By their numbers in this assay, from the lowest: compounds 1, 2 and 3 (each within the scatter of the next, the first and the last beyond it).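

Read in this assay with fluoro in place of nitro on an aromatic carbon, para to a large group, the change comes out as a number 9 percentage points higher from compound 2 to compound 3 (within the scatter) and gives the first direct view of this position: in this pair, growth inhibition at the concentration tested does not depend on the nitro group. Methyl in place of fluoro on an aromatic carbon, elsewhere on the molecule, gives a number 14 percentage points higher from compound 1 to compound 3 (beyond the scatter) and is the only step here beyond the scatter, a modest one resting on a single pair. Nothing at hand bears on why either step has the size it has.

The compounds shown leave open how an amine or a carboxylic acid would fare at the position held by nitro and fluoro. They also leave open whether the methyl step would keep its size with nitro in place of fluoro.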